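From a fluorophenyl to a methylpyridinyl end group

The source may hold more compounds than are shown below. What is called first, only, known or untested is meant among the compounds shown, and "the series" means these compounds.

Two compounds share one core. In an assay on isolated protein for inhibition of tyrosine-protein kinase receptor UFO (Homo sapiens), read by LC-MS (a lower number here means a stronger inhibitor, a higher number a weaker inhibitor), compound 1 `CN(Cc1ccc2nccn2c1)c1nnc(-c2ccc(-c3ccccc3)cc2)o1` gives 3160 nM, and compound 2 `CN(Cc1ccc2nccn2c1)c1nnc(-c2ccc(-c3ccccc3F)cc2)o1` gives 1580 nM. Compound 2 holds the lower of the two numbers, yet the difference a 2.0-fold lower number from compound 1 to compound 2 (0.30 log units; within the scatter) lies within the scatter, so the two cannot be told apart. Compound 3 `Cc1ncccc1-c1ccc(-c2nnc(N(C)Cc3ccc4nccn4c3)o2)cc1` carries 2-methylpyridin-3-yl in place of 2-fluorophenyl on an aromatic carbon. Among the compounds with values here, the only measured step concerns a different exchange and was small, so the expected step is a 1.0-fold higher number from compound 2 to compound 3 (0.01 log units; within the scatter), not beyond the scatter. For compound 3 the estimated value in this assay is 1600 nM, with a range from 500 nM to 5000 nM.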

Compound 3, half-maximal inhibitory concentration: 6310 nM
The estimate for compound 3 lay 3.9-fold (0.60 log units) below the measured number, and the stated range ends below it.
By their numbers in this assay, from the lowest: compounds 2, 1 and 3 (each within the scatter of the next, the first and the last beyond it).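

In this assay, the end group at this position can move the number beyond the scatter: a 4.0-fold higher number from compound 2 to compound 3 (0.60 log units; beyond the scatter) comes with 2-methylpyridin-3-yl replacing 2-fluorophenyl. Against the plain phenyl, a 2.0-fold higher number from compound 1 to compound 3 (0.30 log units; within the scatter) stays small, so those two cannot be told apart. Nothing available explains the step. Still open, as far as these compounds go, is whether the ring nitrogen or the methyl carries the step, which an unsubstituted pyridin-3-yl or a 2-methylphenyl would help separate.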